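Oxazole for Pyrazole on a Shared Fused Core

A few compounds are considered here, and "the series" means these few. Any claim that something is new, unique, unknown or untested is made for them only; others in the source may bear on it.

Of the compounds shown here, three sharing one core have been measured in a functional assay on CHO cells for agonist activity at Alpha-1A adrenergic receptor (Homo sapiens), read by FLIPR and calcium flux; a higher number here means a larger maximal response, a lower number a smaller maximal response. Compound 1 `COc1c(Cl)ccc2c1CCC2c1ncc[nH]1` gives 24%, compound 3 `COc1c(C)ccc2c1CCC2c1ncc[nH]1` gives 40%, and compound 2 `Cn1cc(-c2cccc3c2CCC3c2ncc[nH]2)cn1` gives 12%, the lowest of the three. Among the compounds with values here, the only step between neighbours, a number 16 percentage points higher from compound 1 to compound 3 (beyond the scatter), concerns a substituent of another kind. Compound 4 `c1cc(-c2ncco2)c2c(c1)C(c1ncc[nH]1)CC2` is not yet measured; it differs from compound 2 by 1,3-oxazol-2-yl in place of 1-methyl-1H-pyrazol-4-yl on an aromatic carbon. Within the data shown here, no measured step exchanges one five-membered aromatic ring for another, so that step offers no direct guide, and the account expects a shift of at most modest size in this assay, in no firm direction. Compound 4 is estimated at 15%, within 2% to 38%. This estimate implies a step of a number 3 percentage points higher from compound 2 to compound 4 (within the scatter), expected to stay within the scatter.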

Compound 4, largest response reached (Emax), in percent of the reference or control that the assay uses: 63%
Compound 4: middle estimate off by 48 percentage points, on the low side; the whole stated range lies below it.
By their numbers in this assay, from the lowest: compound 2; then compound 1; then compound 3; then compound 4.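

In this assay, 1,3-oxazol-2-yl in place of 1-methyl-1H-pyrazol-4-yl on this aromatic carbon gives a number 51 percentage points higher from compound 2 to compound 4 (beyond the scatter), so exchanging one five-membered aromatic ring for another can change the maximal response greatly here. The two groups have the same counts of hydrogen-bond donors and acceptors, so those counts do not separate them. Nothing shown here accounts for the step. The compounds shown leave open what an amine or a carboxylic acid on this carbon would give, and whether 1,3-oxazol-2-yl would give a similar step alongside other substituents.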